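A benzylamino swap with no measured guide

The compounds below may be only part of what the source reports. "The series", "measured", "known", "first", "only" and "open" are said of these compounds alone.

Within the data shown here, in a functional assay on MDA-MB-231 cells (Homo sapiens) for antiproliferative activity, read by MTT assay, with a stated time of 24 h (a higher number here means a weaker inhibitor, a lower number a stronger inhibitor), compound 3 (`CCCCc1oc2ccccc2c1C(=O)c1cc(I)c(OCCCN2CCN(C)CC2)c(I)c1`) gives 8760 nM, the only actual number among the compounds measured so far. Compound 1 (`CCCCc1oc2ccccc2c1C(=O)c1ccc(OCCCC(=O)N[C@@H](C)c2ccccc2)cc1`) reads > 50000 nM, which is a limit of the assay and not a number. Compound 2 (`CCCCc1oc2ccccc2c1C(=O)c1ccc(OCCCC(=O)N[C@H](C)c2ccccc2)cc1`) reads > 50000 nM, which is again a limit.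

Compound 4 (`CCCCc1oc2ccccc2c1C(=O)c1cc(I)c(OCCCNCc2ccccc2)c(I)c1`) has not yet been measured. Its structure departs from that of compound 3 in one place: benzylamino in place of 4-methylpiperazin-1-yl on a saturated chain carbon, three bonds along the chain from an oxygen on an aromatic ring. In plain terms, a six-membered aromatic ring of carbon only takes the place of a six-membered non-aromatic ring.

Among the measured compounds shown here, the only measured step is a step that the two limits leave unreadable from compound 1 to compound 2. It rests on the limit of > 50000 nM in this assay, at which 2 of the 3 values shown sit, and on (the fact that compounds 1 and 2 differ only in the configuration as drawn), so it offers no size to carry over to this change. For the measured compounds named here, with no measured step to guide the swap, the starting point remains compound 3 at 8760 nM, and no step beyond the usual scatter is expected in this assay, in either direction, although the uncertainty is wide. The expected step is a 1.1-fold lower number from compound 3 to compound 4 (0.04 log units; within the scatter). The value expected for compound 4 is 8000 nM, with an estimated range from 2500 nM to 28000 nM.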

Compound 4, half-maximal inhibitory concentration: 11600 nM
For compound 4 the middle estimate is 1.5-fold (0.16 log units) below the measured one; low and high end bracket the measured number.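

In this assay, putting benzylamino in place of 4-methylpiperazin-1-yl gives a 1.3-fold higher number from compound 3 to compound 4 (0.12 log units; within the scatter) and provides the first readable step among the compounds shown. It shows that, for this one pair, a six-membered aromatic ring of carbon only can take the place of a six-membered non-aromatic ring with 2 hetero atoms on this saturated chain carbon without a shift beyond the usual scatter, even though the hydrogen-bond donor and acceptor counts of the two groups differ; the earlier step between compounds 1 and 2 cannot be read, so it could not show this. With a step this small, there is no shift to explain, and nothing measured here bears on how either group acts at this place.

Still open, from the compounds shown here alone, is whether a smaller amine such as dimethylamino, a morpholin-4-yl ring or a carboxylic acid at the same place would also stay within the scatter of this pair, or would move the number clearly in either direction. Also open, going by these compounds, is whether a longer chain than the propyl chain in 3-(benzylamino)propyl would change the reading in this cell assay.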